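Ester in place of the benzylic amide on the shared core

The compounds below may be only part of what the source reports. "The series", "measured", "known", "first", "only" and "open" are said of these compounds alone.

Measured compounds in a functional assay on HEY cells (Homo sapiens) for cytotoxicity, read by MTT assay, with a stated time of 72 h; a higher number here means a weaker inhibitor, a lower number a stronger inhibitor:
compound 1 `COc1cccc(CNC(=O)c2nc(Br)c3cccnc3c2N[C@H]2CC[C@H](N)CC2)c1`: 7000 nM
compound 2 `N[C@H]1CC[C@H](Nc2c(C(=O)NCc3ccc(Oc4ccccc4)cc3)nc(Br)c3cccnc23)CC1`: 9000 nM
compound 3 `N[C@H]1CC[C@H](Nc2c(C(=O)NCc3ccccn3)nc(Br)c3cccnc23)CC1`: > 20000 nM, a limit of the assay rather than a number

Compound 3 sits at the weak end of the three: its value is only a limit, (the limit of > 20000 nM in this assay, at which 1 of the 3 values shown sits), so its true number is not known. Among the measured compounds shown here, the one single-point step among the measured compounds runs into it, an at least 2.8-fold higher number from compound 1 to compound 3 (0.45 log units; beyond the scatter); compounds 1 and 2 stand within the scatter of each other.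

Compound 4 `COC(=O)c1nc(Br)c2cccnc2c1N[C@H]1CC[C@H](N)CC1` is not yet measured. It differs from compound 3 as follows: methoxy in place of ((pyridin-2-yl)methyl)amino on a carbonyl carbon. For the measured compounds named here, no measured step touches the carbonyl carbon, so none bears on this change; the only measured step concerns the group on the saturated chain carbon that leaves here altogether. With compound 3 already at the limit, the step that the limit leaves unreadable from compound 3 to compound 4 is expected to stay close to it, with a fair chance of another limit. For compound 4 the estimate is 25000 nM, between 8000 nM and 80000 nM.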

Compound 4, half-maximal inhibitory concentration: > 20000 nM
Compound 4: only a limit was reported; the forecaster's own chance of this, stated with the estimate: 60%; the middle value does not contradict the limit.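

At the carbonyl carbon, in this assay, methoxy in place of (3-methoxybenzyl)amino gives an at least 2.8-fold higher number from compound 1 to compound 4 (0.45 log units; beyond the scatter). Among the compounds shown here, this is the first measured change at this carbon, and it shows that the activity of compound 1 does not survive replacement of its whole amide side by the small methoxy group. The values of compound 3 and compound 4 are both limits, so the step between them cannot be read and the two cannot be ranked: the limit of > 20000 nM in this assay, at which 2 of the 4 values shown sit.

The compounds shown do not separate the loss of the amide hydrogen from the loss of the aromatic ring, as both leave together in this change. A 3-methoxybenzyl ester or a carboxylic acid on the carbonyl carbon would bear on that question, and neither is among them.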